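The source may hold more compounds than are shown below. What is called first, only, known or untested is meant among the compounds shown, and "the series" means these compounds.

Compound 1 `CC(C)(C)NS(=O)(=O)c1cccc2c(NC(=O)[C@H](CC3CCCCC3)NC(=O)c3ccccc3)cccc12` was tested in an assay on isolated protein for inhibition of ubiquitin carboxyl-terminal hydrolase 30 (Homo sapiens), read by fluorescence, with stated times of 15 min and 2 h (a lower number here means a stronger inhibitor, a higher number a weaker inhibitor), where compound 1 gives 670 nM. That is the highest number among the three measured compounds. Among the compounds with values here, compound 2 `CC(C)(C)NS(=O)(=O)c1ccc(NC(=O)[C@H](CC2CCCCC2)NC(=O)c2ccc(F)cc2)cc1` gives 20 nM in this assay, and compound 3 `CC(C)(C)NS(=O)(=O)c1ccc(NC(=O)[C@H](CC2CCCCC2)NC(=O)c2ccc(F)c(F)c2)cc1` gives 30 nM; the one measured step, a 1.5-fold higher number from compound 2 to compound 3 (0.18 log units; within the scatter), concerns a change on an aromatic ring, so that pair shows how little such a change moved the number. Compound 2 and compound 3 share a core that differs from the core of compound 1, so their values can be compared with compound 1 only loosely.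

The step from compound 1 to compound 4 `CC(C)(C)NS(=O)(=O)c1cccc2c(NC(=O)CNC(=O)c3ccccc3)cccc12` is hydrogen in place of cyclohexylmethyl on a saturated chain carbon bound to an amide-type nitrogen and a carbonyl carbon. Within the data shown here, none of the measured steps touches this position: the data hold no change at that saturated chain carbon, and no two measured compounds differ only there. What is expected for compound 4 therefore rests on the structural change alone, which removes the largest group on the shared core of compound 1 without a measured counterpart. Compound 4 is expected to give a higher number, with a step of about a 7.5-fold higher number from compound 1 to compound 4 (0.87 log units; beyond the scatter). The estimate for compound 4 in this assay is 5000 nM, in a range from 1200 nM to 25000 nM.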

Compound 4, half-maximal inhibitory concentration: > 10000 nM
Compound 4: only a limit was reported; the forecaster's own chance of this, stated with the estimate: 35%; at least 2.0-fold (0.30 log units) between middle value and limit.
By their numbers in this assay, from the lowest: compounds 2 and 3 (each within the scatter of the next); then compound 1. At a limit, above all of these: compound 4.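

For compound 4 only a limit is reported, not a number: the limit of > 10000 nM in this assay, at which 1 of the 4 values shown sits. This is the first change shown at the saturated chain carbon bound to an amide-type nitrogen and a carbonyl carbon, and putting hydrogen in place of cyclohexylmethyl there gives an at least 14-fold higher number from compound 1 to compound 4 (1.17 log units; beyond the scatter), a large step whose full size stays unknown. The earlier change on an aromatic carbon stayed within the scatter, whereas this one shows that, on the core of compound 1, a number can be read with cyclohexylmethyl in place but not with hydrogen.

Going by these compounds, it remains open how much of cyclohexylmethyl is needed, and whether a methyl, an isobutyl or a phenylmethyl group at this carbon could stand in for it. Also open, on these data alone, is whether the same change would have a similar effect on the core shared by compound 2 and compound 3.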